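This account rests on a few compounds, and the source may have more. Where it says the series, first, only, none or still open, it means among the compounds named here.

Compound 1 `COc1cccc(/C=C/C(=O)c2ccc(OC)c(N)c2)c1` stands at the top of the two numbers shown, its gap to the only other measured compound being within the scatter. In a functional assay on B16 cells (Mus musculus) for cytotoxicity, read by MTT assay, with a stated time of 3 days (on this read-out lower numbers stand for stronger inhibition and higher numbers for weaker inhibition), compound 1 gives 33000 nM. Compound 2 `COc1ccc(C(=O)/C=C/c2ccc(OC)c(OC)c2)cc1N` gives 18000 nM, reached by the step of a 1.8-fold lower number from compound 1 to compound 2 (0.26 log units; within the scatter). Compound 3 `COc1ccc(OC)c(/C=C/C(=O)c2ccc(OC)c(N)c2)c1` differs from compound 1 by methoxy in place of hydrogen on an aromatic carbon, entering ortho to a large group and para to a methoxy group. Within the data shown here, only that one measured step bears on this change, and it stayed within the scatter, so no step beyond the scatter is expected in this assay. Compound 3 is estimated at 25000 nM, between 10000 nM and 70000 nM. This expected step is a 1.3-fold lower number from compound 1 to compound 3 (0.12 log units; within the scatter).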

Compound 3, half-maximal inhibitory concentration: 5600 nM
Beside the measured number, compound 3's estimate is 4.5-fold (0.65 log units) above it; measured number outside the range, below it.
By their numbers in this assay, from the lowest: compound 3; then compounds 2 and 1 (each within the scatter of the next).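

In this assay, methoxy entering ortho to a large group and para to a methoxy group gives a 5.9-fold lower number from compound 1 to compound 3 (0.77 log units; beyond the scatter) and so moves the number beyond the scatter. The same replacement of hydrogen by methoxy at another place gives only a 1.8-fold lower number from compound 1 to compound 2 (0.26 log units; within the scatter) and stays within the scatter, so on this core the place of entry counts, not merely the group. Nothing available explains this difference.

Going by these compounds, whether a hydroxyl, an ethoxy or an amine at this same place would also lower the number remains open.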